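The source may hold more compounds than are shown below. What is called first, only, known or untested is meant among the compounds shown, and "the series" means these compounds.

Working notes on the series. In a functional assay on HOP-62 cells (Homo sapiens) for antiproliferative activity, read by sulforhodamine B assay, with a stated time of 48 h (a lower number here means a stronger inhibitor, a higher number a weaker inhibitor), compound 1 (`C/C=C(\C)C(=O)O[C@H]1C=CC(=O)O[C@H]1CCC(=O)[C@H](C)O`) gives 26000 nM and compound 2 (`C/C=C(\C)C(=O)O[C@H]1C=CC(=O)O[C@H]1COC(=O)[C@H](C)O`) gives 19000 nM. Among the compounds with values here, these two values lie within the scatter of each other, so compound 2 stands level with compound 1 on the only numbers available.

The next compound is compound 3 (`C/C=C(\C)C(=O)O[C@H]1C=CC(=O)O[C@H]1CNC(=O)[C@H](C)O`). It carries ((1-hydroxyethyl)carbonyl)amino in place of ((1-hydroxyethyl)carbonyl)oxy on a saturated chain carbon bound to a saturated ring carbon.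

Within the data shown here, one measured step bears on this change, as it is an exchange at the same place: a 1.4-fold lower number from compound 1 to compound 2 (0.14 log units; within the scatter). That step stayed within the scatter. Among the measured compounds shown here, it is a single step, and no measured compound yet carries the amino group, so the evidence is thin. On that basis, no step beyond the scatter is expected in this assay, and no direction can be favoured. The estimated step is a 1.1-fold higher number from compound 2 to compound 3 (0.02 log units; within the scatter). For compound 3 the expected value is 20000 nM, with an estimated range of 9000 nM to 45000 nM.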

Compound 3, half-maximal inhibitory concentration: 27000 nM
Compound 3: middle estimate off by 1.4-fold (0.13 log units), on the low side; the measured number falls inside the stated range.
By their numbers in this assay, from the lowest: compounds 2, 1 and 3 (each within the scatter of the next).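

With compound 3 in hand, this place has been read with three different linking atoms, and this assay separates none of them: the exchange of ((1-hydroxyethyl)carbonyl)oxy for ((1-hydroxyethyl)carbonyl)amino gives a 1.4-fold higher number from compound 2 to compound 3 (0.15 log units; within the scatter) and the exchange of ((1-hydroxyethyl)carbonyl)methyl for ((1-hydroxyethyl)carbonyl)amino gives a 1.0-fold higher number from compound 1 to compound 3 (0.02 log units; within the scatter). Within the data shown here, compounds 1, 2 and 3 therefore stand level, and the one step available earlier is now joined by two more of the same kind, all on a saturated chain carbon bound to a saturated ring carbon. The move to the amino group also alters the hydrogen-bond donor and acceptor counts, yet no step beyond the scatter comes with it, and nothing measured here accounts for this level reading.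

All three compounds keep the same (1-hydroxyethyl)carbonyl end, so these numbers say nothing about how a carboxylic acid, a primary amine or a longer alkyl chain would read at this place. From the compounds shown here alone, whether a methyl group on the amide nitrogen, or the removal of the hydroxyl from the 1-hydroxyethyl group, would produce a step beyond the scatter also remains open.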